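Working notes: chloro added to compound 1

A few compounds are considered here, and "the series" means these few. Any claim that something is new, unique, unknown or untested is made for them only; others in the source may bear on it.

Compound 1 `Clc1cccc(Cn2cc(COc3ccccc3)nn2)c1`: > 100 ug/mL
Compound 2 `Brc1ccc(Cn2cc(COc3ccccc3)nn2)cc1`: > 100 ug/mL

In an ADME assay on PANC-1 cells (Homo sapiens) for inhibition, read by MTT assay, with a stated time of 48 h (on this read-out lower numbers stand for stronger inhibition of growth and higher numbers for weaker inhibition of growth), compound 1 gives > 100 ug/mL, which is a limit and not a number. Compound 2 gives > 100 ug/mL, also a limit. Going by the values given here, the series so far stands at the limit of > 100 ug/mL in this assay, at which 2 of the 2 values shown sit.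

Compound 3 `Clc1ccc(OCc2cn(Cc3cccc(Cl)c3)nn2)cc1` differs from compound 1 by chloro in place of hydrogen on an aromatic carbon. Among the compounds with values here, the only measured step is a step that the two limits leave unreadable from compound 1 to compound 2, so it offers no size to carry over. No step beyond the scatter is therefore expected in this assay, and no direction is supported. The estimated step is a number no higher from compound 1 to compound 3 (the limit leaves the size open). Compound 3 is expected at 100 ug/mL, within an estimated range of 40 ug/mL to 200 ug/mL.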

Compound 3, concentration for 50% growth inhibition: > 100 ug/mL
Compound 3 gave a limit, no number (the forecaster's own chance of this, stated with the estimate: 70%); the middle value sits exactly at the limit.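

Compound 1 and compound 3 each give only a limit in this assay, so no step can be read between them. The compounds shown leave open whether chloro in place of hydrogen changes growth inhibition at all: the limit of > 100 ug/mL in this assay, at which 3 of the 3 values shown sit.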